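Sulfanyl to sulfonyl at the aryl ether chain: compound 3

A few compounds are considered here, and "the series" means these few. Any claim that something is new, unique, unknown or untested is made for them only; others in the source may bear on it.

Two members of the series are measured. Compound 1 `CCCCN(O)C(=O)Nc1cc([C@@H]2CC[C@@H](c3cc(OC)c(OC)c(OC)c3)O2)cc(OC)c1OCCS(=O)(=O)c1c(F)c(F)cc(F)c1F` gives 50% in a functional assay on the whole organism for inhibition, with Mus musculus as the target, at a dose of 3 mg/kg; on this read-out lower numbers stand for less inhibition and higher numbers for more inhibition at the one dose given (going by the name of the read-out). Compound 2 `CCCCN(O)C(=O)Nc1cc([C@@H]2CC[C@@H](c3cc(OC)c(OC)c(OC)c3)O2)cc(OC)c1OCCSc1cccc(Br)c1` gives 28% in this assay. On these two numbers compound 2 stands lowest, with compound 1 the nearer and only neighbour, and the gap between them lies beyond the usual scatter. The two compounds differ in more than one place, so no single-point step is available between them, and no cause for the gap can be drawn.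

Compound 3 `CCCCN(O)C(=O)Nc1cc([C@@H]2CC[C@@H](c3cc(OC)c(OC)c(OC)c3)O2)cc(OC)c1OCCS(=O)(=O)c1ccc(Br)cc1` has not been measured in this assay. It arises from compound 2 by the change ((4-bromophenyl)sulfonyl in place of (3-bromophenyl)sulfanyl on a saturated chain carbon, two bonds along the chain from an oxygen on an aromatic ring). Compound 3 thus carries a sulfonyl on the chain, as compound 1 does, although the aryl part differs in both compounds. A step from compound 2 to compound 3 of about a number 12 percentage points higher from compound 2 to compound 3 (beyond the scatter) upward is expected, a modest size near the edge of the scatter, because compound 1 with its sulfonyl gives 50%. For compound 3 the estimate in this assay is 40%, with a range from 20% to 60%.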

Compound 3, a percentage reported as inhibition, in the whole organism at one dose (the size of the read-out at that dose, not a potency): 29%
Beside the measured number, compound 3's estimate is 11 percentage points above it; low and high end bracket the measured number.
By their numbers in this assay, from the lowest: compounds 2 and 3 (each within the scatter of the next); then compound 1.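

In this assay the step is a number 1 percentage points higher from compound 2 to compound 3 (within the scatter), so (4-bromophenyl)sulfonyl in place of (3-bromophenyl)sulfanyl, on a saturated chain carbon, two bonds along the chain from an oxygen on an aromatic ring, gives no separation from the earlier sulfanyl compound, and a sulfonyl on the chain does not by itself go with the higher number seen for compound 1. Going by these compounds alone, with the sulfonyl held in place, 4-bromophenyl in place of 2,3,5,6-tetrafluorophenyl on the sulfonyl sulfur gives a number 21 percentage points lower from compound 1 to compound 3 (beyond the scatter) in this assay, so the gap now sits with the aryl group on the sulfonyl sulfur, and this is the first single-place comparison to show it. No measurement at hand explains either step.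

The step from compound 2 to compound 3 joins the change at sulfur with the move of the bromine, and a (3-bromophenyl)sulfonyl or (4-bromophenyl)sulfanyl group would pull the two apart. Open too, going by these compounds, is which feature of the 2,3,5,6-tetrafluorophenyl group tracks with the higher number, a question that a 4-fluorophenyl or an unsubstituted phenyl on the sulfonyl sulfur would address.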